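The source may report more compounds than this note shows. Statements on the series, on what has been measured and on what is new or still open speak of the compounds shown alone.

Of the compounds shown here, two have been measured in a functional assay on A-375 cells (Homo sapiens) for antiproliferative activity, read by CCK-8 assay, with a stated time of 72 h, tested at 2 uM; on this read-out lower numbers stand for a weaker effect and higher numbers for a stronger effect at the one concentration tested. Compound 1 `Nc1ccccc1NC(=O)c1ccc(CSC(=S)N2CCN(c3ccccc3)CC2)cc1` gives 27.5% in this assay, and compound 2 `Nc1ccccc1NC(=O)c1ccc(CSC(=S)N2CCCc3ccccc32)cc1` gives 26.5% in this assay; compound 1 holds the higher of the two numbers, but the gap to compound 2 lies within the usual scatter, so the two cannot be separated. Going by the values given here, no step between measured compounds that differ in a single place has been recorded, and so nothing in these two numbers shows how a change on the amine nitrogen in the ring moves the read-out. Compound 3 `Nc1ccccc1NC(=O)c1ccc(CSC(=S)N2CCN(Cc3ccncc3)CC2)cc1` differs from compound 1 in one place: (pyridin-4-yl)methyl in place of phenyl on an amine nitrogen in a ring. Among the compounds with values here, with no comparable step to rely on, the step of a number 0.5 percentage points lower from compound 1 to compound 3 (within the scatter) is expected to be small, in neither direction beyond the scatter. Compound 3 is therefore estimated to give 27% in this assay, with a range from 12% to 42%.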

Compound 3, a percentage reported as inhibition, at one concentration (the size of the read-out at that concentration, not a potency): 33.1%
The estimate for compound 3 lay 6.1 percentage points below the measured number, and the stated range covers the measured number.
By their numbers in this assay, from the lowest: compounds 2, 1 and 3 (each within the scatter of the next).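

Going by these compounds alone, the step from phenyl to (pyridin-4-yl)methyl on an amine nitrogen in a ring is the first single-place comparison: in this assay, it gives a number 5.6 percentage points higher from compound 1 to compound 3 (within the scatter). The position therefore takes a group with a hetero atom in its aromatic ring and a hydrogen-bond acceptor, with no shift that can be told apart from the scatter. No measured property of these groups or other supporting data bears on this result.

As far as these compounds go, it remains open whether a carboxylic acid or a dimethylamino group at this ring nitrogen would move the read-out beyond the scatter. The compounds shown also leave open what a longer chain in place of the methyl link of the (pyridin-4-yl)methyl group would do.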